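Fluoro in place of methyl: compound 3 to compound 4

A few compounds are considered here, and "the series" means these few. Any claim that something is new, unique, unknown or untested is made for them only; others in the source may bear on it.

In a functional assay on NCI-H520 cells (Homo sapiens) for cytotoxicity (on this read-out lower numbers stand for stronger inhibition of growth and higher numbers for weaker inhibition of growth), compound 1 (`CSc1ccc(C2=C(c3ccc(C)c(C)c3)C(=O)N3CCCC3C2)cc1`) gives 300 nM, compound 2 (`CSc1ccc(C2=C(c3ccc(F)c(C)c3)C(=O)N3CCCC3C2)cc1`) gives 500 nM and compound 3 (`CSc1ccc(C2=C(c3ccc(C)cc3)C(=O)N3CCCC3C2)cc1`) gives 900 nM. Compound 3 stands apart from compound 1 only: the data show a 3.0-fold higher number from compound 1 to compound 3 (0.48 log units; beyond the scatter), against a 1.8-fold higher number from compound 2 to compound 3 (0.26 log units; within the scatter).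

The next structure, compound 4 (`CSc1ccc(C2=C(c3ccc(F)cc3)C(=O)N3CCCC3C2)cc1`), carries fluoro in place of methyl on an aromatic carbon, para to a large group, the change 4-methylphenyl to 4-fluorophenyl: fluoro in place of methyl on an aromatic carbon.

Within the data shown here, one measured step bears directly on this exchange: a 1.7-fold higher number from compound 1 to compound 2 (0.22 log units; within the scatter). It is a single precedent, and both of its compounds hold a further methyl that compound 3 lacks. A small move toward a higher number is therefore expected in this assay, with no step beyond the scatter anticipated. The expected step is a 1.6-fold higher number from compound 3 to compound 4 (0.19 log units; within the scatter). The estimated value for compound 4 is 1400 nM, with an expected range from 600 nM to 3000 nM.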

Compound 4, concentration for 50% growth inhibition: 250 nM
Beside the measured number, compound 4's estimate is 5.6-fold (0.75 log units) above it, outside the stated range (below it).
By their numbers in this assay, from the lowest: compounds 4, 1, 2 and 3 (each within the scatter of the next, the first and the last beyond it).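

In this assay, fluoro in place of methyl on an aromatic carbon, para to a large group, has no single direction in this series; without the further methyl on the ring it gives a 3.6-fold lower number from compound 3 to compound 4 (0.56 log units; beyond the scatter), and the two cores disagree: the same change on two cores in this assay, a 1.7-fold higher number (0.22 log units; within the scatter) from compound 1 to compound 2 and a 3.6-fold lower number (0.56 log units; beyond the scatter) from compound 3 to compound 4, 6.0-fold (0.78 log units) apart, beyond the scatter of two such steps

The loss of a methyl from the aromatic ring also depends on the rest of the ring, with a 2.0-fold lower number from compound 2 to compound 4 (0.30 log units; within the scatter) as the second reading of that change: the same change on two cores in this assay, a 3.0-fold higher number (0.48 log units; beyond the scatter) from compound 1 to compound 3 and a 2.0-fold lower number (0.30 log units; within the scatter) from compound 2 to compound 4, 6.0-fold (0.78 log units) apart, beyond the scatter of two such steps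

No difference can be claimed between 4-fluorophenyl and 3,4-dimethylphenyl on the double-bonded ring carbon, with a 1.2-fold lower number from compound 1 to compound 4 (0.08 log units; within the scatter), so the exchanges on this ring do not simply add.

From the compounds shown here alone, how this position responds to other groups, such as chloro, methoxy or an amine, remains open. Going by these compounds, with only four compounds, it also remains open whether this dependence on the rest of the ring extends beyond fluoro, methyl and hydrogen.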